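A fluorine swap at the assay's limit

A few compounds are considered here, and "the series" means these few. Any claim that something is new, unique, unknown or untested is made for them only; others in the source may bear on it.

Measured in a functional assay on M21 cells (Homo sapiens) for antiproliferative activity, read by sulforhodamine B assay, with a stated time of 48 h; on this read-out lower numbers stand for stronger inhibition and higher numbers for weaker inhibition:
compound 1 `CCCCN1CCN(c2ccc(S(=O)(=O)Oc3ccccc3OC)cc2)C1=O`: > 100000 nM (a limit)
compound 2 `CCCCN1CCN(c2ccc(S(=O)(=O)Oc3ccc(OC)c(OC)c3)cc2)C1=O`: > 100000 nM (a limit)

Compound 2 has no exact number in this assay, only the limit > 100000 nM. Going by the values given here, the same holds across the series so far, which amounts to the limit of > 100000 nM in this assay, at which 2 of the 2 values shown sit.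

Compound 3 `CCCCN1CCN(c2ccc(S(=O)(=O)Oc3ccc(F)c(F)c3)cc2)C1=O` keeps the shared core and the butyl chain but changes the group on an oxygen whose other neighbour is the sulfonyl sulfur: 3,4-difluorophenyl in place of 3,4-dimethoxyphenyl on an oxygen.

Among the compounds with values here, only one measured step bears on this change: a step that the two limits leave unreadable from compound 1 to compound 2. With no readable size, that step offers no direction to carry forward, so no clear change is expected, and another limit is a likely result.

The expected step is a number no higher from compound 2 to compound 3 (the limit leaves the size open).

For compound 3, the estimated value is 100000 nM, with an expected range from 20000 nM to 200000 nM.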

Compound 3, half-maximal inhibitory concentration: > 100000 nM
Compound 3 ended at the assay's limit (the forecaster's own chance of this, stated with the estimate: 75%); the middle value lies on the limit itself.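

Going by these compounds alone, compound 3 gives a limit rather than a number, as do compound 1 and compound 2, so no step among the three can be read: the limit of > 100000 nM in this assay, at which 3 of the 3 values shown sit. From the compounds shown here alone, whether the group on that oxygen affects inhibition in these cells stays open: none of the three compounds has an exact number to compare.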